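This account rests on a few compounds, and the source may have more. Where it says the series, first, only, none or still open, it means among the compounds named here.

Three compounds built on closely related cores were tested in a functional assay on MDA-MB-231 cells (Homo sapiens) for antiproliferative activity, read by MTT assay, with a stated time of 48 h; a lower number here means a stronger inhibitor, a higher number a weaker inhibitor. Compound 1 `CS(=O)(=O)c1ccc(Nc2ncc(F)c(Nc3nc4ccccc4s3)n2)cc1` gave 4980 nM. Compound 2 `COc1ccc2nc(Nc3nc(Nc4ccc(S(C)(=O)=O)cc4)ncc3F)sc2c1` gave 4740 nM in this assay. Compound 3 `COc1ccc2nc(Nc3ccnc(Nc4ccc(S(N)(=O)=O)cc4)n3)sc2c1` gave 6240 nM, and the difference between the core of compound 3 and the core of compound 2 is not broken down here; the two values sit within the usual scatter of one another.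

Compounds 2 and 1 differ in one place (hydrogen in place of methoxy on an aromatic carbon). This change gave a 1.1-fold higher number from compound 2 to compound 1 (0.02 log units; within the scatter).

Compound 4 `NS(=O)(=O)c1ccc(Nc2nccc(Nc3nc4ccccc4s3)n2)cc1` has not yet been measured in this assay. It differs from compound 3 in the same way (hydrogen in place of methoxy on an aromatic carbon), and the surroundings of the place are the same in both pairs, so the change is the same. An estimated step of a 1.1-fold higher number from compound 3 to compound 4 (0.03 log units; within the scatter) is expected, resting on the observation that this change gave a 1.1-fold higher number from compound 2 to compound 1 (0.02 log units; within the scatter). Compound 4 is therefore expected to give about 6700 nM in this assay, with a plausible range from 3300 nM to 13500 nM.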

Compound 4, half-maximal inhibitory concentration: 5000 nM
Compound 4: middle estimate off by 1.3-fold (0.13 log units), on the high side; the measured number falls inside the stated range.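

In this assay, hydrogen in place of methoxy on an aromatic carbon gave a 1.2-fold lower number from compound 3 to compound 4 (0.10 log units; within the scatter). Set beside the earlier step, the result on the two cores agrees: the same change on two cores in this assay, a 1.1-fold higher number (0.02 log units; within the scatter) from compound 2 to compound 1 and a 1.2-fold lower number (0.10 log units; within the scatter) from compound 3 to compound 4, 1.3-fold (0.12 log units) apart, within the scatter of two such steps On these two cores, then, the exchange leaves the number within the scatter, and that absence of a measurable step carries from one core to the other, but this does not show that it would hold on a further core, nor does it give a real effect of any size to transfer.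

Going by these compounds, whether another group on that aromatic carbon, such as an ethoxy chain, a chlorine atom or an amine, would give a step beyond the scatter remains open. Also open is what each of the other differences between the two cores contributes, since no pair shown isolates any of them.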